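The compounds below may be only part of what the source reports. "The series", "measured", "known", "first", "only" and "open" are said of these compounds alone.

Compound 1 `Cn1cncc1C(OCc1nc(N2CCC(O)CC2)c(C#N)cc1-c1cccc(Cl)c1)c1ccc(C#N)cc1`: 830 nM
Compound 2 `Cn1cncc1C(OCc1ccc(C#N)nc1-c1ccc(OC(F)(F)F)cc1)c1ccc(C#N)cc1`: 1200 nM

Both numbers come from an assay on isolated protein (Bos taurus) for inhibition of geranylgeranyl transferase type-1 subunit beta (Homo sapiens); a higher number here means a weaker inhibitor, a lower number a stronger inhibitor. Compound 2 shows the higher of the two numbers, but its gap to compound 1 lies within the scatter, so the two cannot be told apart. Compound 3 `Cn1cncc1C(OCc1ccc(C#N)nc1-c1ccc2ccccc2c1)c1ccc(C#N)cc1` differs from compound 2 by naphthalen-2-yl in place of 4-(trifluoromethoxy)phenyl on an aromatic carbon. Within the data shown here, no step between two measured compounds is available to gauge such a change, so in this assay the step is expected to be small, in no clear direction, and likely within the scatter. The expected step is no change at the digits printed from compound 2 to compound 3 (within the scatter). Compound 3 is therefore estimated at 1200 nM, with a range from 400 nM to 3600 nM.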

Compound 3, half-maximal inhibitory concentration: 5500 nM
Beside the measured number, compound 3's estimate is 4.6-fold (0.66 log units) below it, outside the stated range (above it).
By their numbers in this assay, from the lowest: compounds 1 and 2 (each within the scatter of the next); then compound 3.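

In this assay the group on the aromatic carbon next to the ring nitrogen clearly affects the number: naphthalen-2-yl in place of 4-(trifluoromethoxy)phenyl gives a 4.6-fold higher number from compound 2 to compound 3 (0.66 log units; beyond the scatter). Among these compounds, this is the first change measured at this place, and here the two-ring group gives the weaker inhibitor. Nothing measured here explains the step. From the compounds shown here alone, it remains open whether the second ring, the absence of the trifluoromethoxy group, or both account for the difference. Unsubstituted phenyl at this place could help separate these possibilities.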